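Swapping the aryl group on the hydrazone carbon of compound 2

The source may report more compounds than this note shows. Statements on the series, on what has been measured and on what is new or still open speak of the compounds shown alone.

Measured compounds and their numbers:
compound 1 `CN(C)C/C=C/C(=O)Nc1cccc(Nc2nc(N/N=C/c3ccncc3)ncc2Cl)c1`, 25200 nM
compound 2 `C/C(=N\Nc1ncc(Cl)c(Nc2cccc(NC(=O)/C=C/CN(C)C)c2)n1)c1ccc(F)cc1F`, 3460 nM

In an ADME assay on HT-29 cells (Homo sapiens) for inhibition, read by MTT assay, with a stated time of 72 h (on this read-out lower numbers stand for stronger inhibition and higher numbers for weaker inhibition), compound 2 gives 3460 nM, the lowest of the two numbers shown, and compound 1 gives 25200 nM. For the measured compounds named here, the one measured step, a 7.3-fold lower number from compound 1 to compound 2 (0.86 log units; beyond the scatter), came from exchanging the group attached to a nitrogen on an aromatic ring, where a six-membered aromatic ring with one hetero atom gave way to a carbon-only aromatic ring carrying two fluorines.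

Compound 3 `C/C(=N\Nc1ncc(Cl)c(Nc2cccc(NC(=O)/C=C/CN(C)C)c2)n1)c1cccnc1` has not yet been measured. It differs from compound 2 by pyridin-3-yl in place of 2,4-difluorophenyl on a carbon with a double bond to nitrogen. This change partly undoes what separated compound 1 from compound 2: a carbon-only ring with two fluorines leaves and a six-membered aromatic ring with one hetero atom returns, while the saturated chain carbon on the same carbon is kept. Because a 7.3-fold lower number from compound 1 to compound 2 (0.86 log units; beyond the scatter) lay beyond the scatter, a step upward in this assay is expected for compound 3, though smaller than that whole step since only part of it is reversed. Compound 3 is therefore estimated at 10000 nM, with a range from 3500 nM to 30000 nM, which means an expected step of a 2.9-fold higher number from compound 2 to compound 3 (0.46 log units; beyond the scatter).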

Compound 3, half-maximal inhibitory concentration: 9660 nM
Estimate against measurement, compound 3: 1.0-fold (0.02 log units) above; the range from low to high includes it.
By their numbers in this assay, from the lowest: compound 2; then compound 3; then compound 1.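

In this assay, the exchange on the carbon with a double bond to nitrogen gives a 2.8-fold higher number from compound 2 to compound 3 (0.45 log units; beyond the scatter), which shows that this place responds to the aryl group alone while the saturated chain carbon stays in place. The second step, a 2.6-fold lower number from compound 1 to compound 3 (0.42 log units; beyond the scatter), joins two groups that each carry a six-membered aromatic ring with 1 hetero atom, so a lower number than that of compound 1 is reached without the 2,4-difluorophenyl group, and the earlier step between compound 1 and compound 2 now divides into two parts, each beyond the scatter. Nothing given here explains either step.

The compounds shown cannot separate the two fluorines from the carbon-only ring that bears them, a question that plain phenyl or a 4-fluorophenyl group on the same carbon would address. They also leave open how the saturated chain carbon itself contributes, since compound 1 and compound 3 differ in the attachment of the ring as well, and an ethyl group or a hydrogen on that carbon, with pyridin-3-yl kept, would test this.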